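This account rests on a few compounds, and the source may have more. Where it says the series, first, only, none or still open, it means among the compounds named here.

Working notes on the series. In a functional assay on the whole organism with Rattus norvegicus as the target (a higher number here means that more compound is needed for the effect, a lower number that less compound is needed), compound 1 `Nc1ccc2nc(N)sc2c1` gives > 10 mg/kg, which is a limit of the assay and not a number. Compound 2 `Nc1nc2ccc(C3CCCCC3)cc2s1` gives > 10 mg/kg, again a limit. Going by the values given here, the series therefore stands at the limit of > 10 mg/kg in this assay, at which 2 of the 2 values shown sit, so compound 1 has no number to measure from, and no step between measured compounds is available.

The next compound is compound 3 `CCCc1ccc2nc(N)sc2c1`. Here propyl replaces amino on an aromatic carbon of the core of compound 1: propyl in place of amino on an aromatic carbon.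

Among the compounds with values here, with no measured step as a guide, the expectation is only a modest move towards a lower dose, and a further limit remains a real possibility. Caution is warranted since compound 2, which carries no amino group in that place either, reads > 10 mg/kg. The expected size of the change is an at least 1.2-fold lower number from compound 1 to compound 3 (0.09 log units; that floor lies within the scatter), an estimate that leans on a limit. For compound 3 the estimated dose for half-maximal effect is 8 mg/kg, with an expected range of 3 mg/kg to 25 mg/kg.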

Compound 3, dose for half-maximal effect: 6 mg/kg
Estimate against measurement, compound 3: 1.3-fold (0.12 log units) above; the range from low to high includes it.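

In this assay, going by these compounds alone, compound 3 is the first compound of the series to give a number and not a limit, so the place that holds amino in compound 1 can carry a group that brings the dose within the range of the assay. Propyl in place of amino gives an at least 1.6-fold lower number from compound 1 to compound 3 (0.22 log units; that floor lies within the scatter); this figure is only a floor set by a limit, so the full size of the step remains unknown, and the floor itself does not clear the scatter. Propyl has 0 hydrogen-bond donors and 0 hydrogen-bond acceptors, so a measurable dose at this place does not depend on the donor and acceptor counted on amino, although most of the series still gives no number: the limit of > 10 mg/kg in this assay, at which 2 of the 3 values shown sit.

Compound 2 gives > 10 mg/kg, which is a limit, so its cyclohexyl group offers no number to set against propyl. As far as these compounds go, how the dose follows chain length at this place stays open, as does the outcome with a shorter ethyl chain, a longer butyl chain, or a chain ending in a carboxylic acid.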